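The source may report more compounds than this note shows. Statements on the series, on what has been measured and on what is new or still open speak of the compounds shown alone.

The measured compounds and their values:

compound 1, `CC1=C(C(=O)Nc2ccc(Br)cc2)C(c2ccc(Cl)cc2Cl)N=C(SCc2ccccc2)N1`: 3.6%
compound 2, `CC1=C(C(=O)Nc2ccc(Br)cc2)C(c2ccc(Cl)cc2Cl)N=C(SCc2cccc(Cl)c2)N1`: 3.1%
compound 3, `CC1=C(C(=O)Nc2ccc([N+](=O)[O-])cc2)C(c2ccc(Br)cc2)N=C(SCc2ccccc2)N1`: 3.6%

All three were tested in a functional assay on the whole organism (artery, strain albino) with Rattus norvegicus as the target, with a stated time of 30 min, at a dose of 10 mg/kg by the oral route; on this read-out higher numbers stand for more inhibition at the one dose given (going by the name of the read-out) and lower numbers for less inhibition. Compound 1 gives 3.6%, and compound 2, which differs from it by chloro in place of hydrogen on an aromatic carbon, gives 3.1%. This step is a number 0.5 percentage points lower from compound 1 to compound 2 (within the scatter), so the two numbers cannot be told apart. Compound 3 gives 3.6% in this assay; how its core differs from that of compound 1 is not broken down here. Its value is level with that of compound 1 at the digits printed, and the gap to compound 2 is also within the scatter, so no ordering among the three can be drawn.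

Compound 4, `CC1=C(C(=O)Nc2ccc([N+](=O)[O-])cc2)C(c2ccc(Br)cc2)N=C(SCc2ccccc2Cl)N1`, has not yet been measured. It differs from compound 3 by chloro in place of hydrogen on an aromatic carbon. This is the same kind of change as that from compound 1 to compound 2, though not the same: in compound 4 the chloro sits ortho to a large group, whereas in compound 2 it sits meta to a large group. Within the data shown here, since the one measured instance of this kind of change, a number 0.5 percentage points lower from compound 1 to compound 2 (within the scatter), stayed within the scatter, the step from compound 3 to compound 4 is expected to be a number 0.1 percentage points lower from compound 3 to compound 4 (within the scatter). On that basis compound 4 is estimated to give 3.5% in this assay, with a likely range from 0% to 12%.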

Compound 4, a percentage reported as inhibition, in the whole organism at one dose (the size of the read-out at that dose, not a potency): 3.6%
Beside the measured number, compound 4's estimate is 0.1 percentage points below it, and the stated range covers the measured number.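

In this assay, chloro in place of hydrogen on an aromatic carbon of the benzyl group gives no change at the digits printed from compound 3 to compound 4 (within the scatter). Set beside the earlier step, the change reads the same on both cores, with neither step separable from the scatter: the same change on two cores in this assay, a number 0.5 percentage points lower (within the scatter) from compound 1 to compound 2 and no change at the digits printed (within the scatter) from compound 3 to compound 4, 0.5 percentage points apart, within the scatter of two such steps This shows only that on these two cores the added chloro leaves the read-out where it was, at one oral dose and one stated time, and it does not show that the change is without effect in general, since there are only two instances, both starting from low numbers, so a core giving a much larger inhibition might respond differently, and a chloro at any other place on the ring might too.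

The compounds shown leave open whether any other group on the benzyl ring, such as a methoxy group, an amine or a carboxylic acid, or a longer chain in place of the benzyl group on the sulfur, would lift the number clear of the scatter. They also leave open what a group such as a hydroxyl or an amine would do in place of the bromo or nitro group on the amide's aromatic ring.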